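From 5-bromofuran-2-yl to 5-methylfuran-2-yl

This account rests on a few compounds, and the source may have more. Where it says the series, first, only, none or still open, it means among the compounds named here.

Values measured in a functional assay on NCI-H460 cells (Homo sapiens) for cytotoxicity, read by MTT assay, with a stated time of 72 h (a higher number here means a weaker inhibitor, a lower number a stronger inhibitor), are these:
Compound 1 `O=c1[nH]/c(=C\c2nc[nH]c2C2CC2)c(=O)[nH]/c1=C\c1cccc(Oc2ccc(F)cc2)c1` gives 15.2 nM
Compound 2 `O=c1[nH]/c(=C\c2ccccn2)c(=O)[nH]/c1=C\c1cccc(Oc2ccc(F)cc2)c1` gives 49.1 nM
Compound 3 `O=c1[nH]/c(=C\c2ccc(Br)o2)c(=O)[nH]/c1=C\c1cccc(Oc2ccc(F)cc2)c1` gives 361 nM

Compound 3 has the highest number of the three, shown by a 7.4-fold higher number from compound 2 to compound 3 (0.87 log units; beyond the scatter) and by a 24-fold higher number from compound 1 to compound 3 (1.38 log units; beyond the scatter) in this assay as well. Compound 4 `Cc1ccc(/C=c2\[nH]c(=O)/c(=C/c3cccc(Oc4ccc(F)cc4)c3)[nH]c2=O)o1` keeps the shared core and carries methyl in place of bromo on an aromatic carbon of the same ring. Going by the values given here, no measured step makes this exchange: all three, including a 3.2-fold higher number from compound 1 to compound 2 (0.51 log units; beyond the scatter) as the smallest, replace the whole aromatic group. With the ring kept, a smaller step than those is expected, modest at most and only tentatively downward. The estimated change is a 1.8-fold lower number from compound 3 to compound 4 (0.26 log units; within the scatter) by this reasoning. For compound 4 the expected value in this assay is 200 nM (70 nM to 550 nM) by this estimate.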

Compound 4, half-maximal inhibitory concentration: 30 nM
Estimate against measurement, compound 4: 6.7-fold (0.82 log units) above; measured number outside the range, below it.
By their numbers in this assay, from the lowest: compounds 1, 4 and 2 (each within the scatter of the next, the first and the last beyond it); then compound 3.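

In this assay, with the ring kept, exchanging the single heavy atom next to the ring oxygen gives a 12-fold lower number from compound 3 to compound 4 (1.08 log units; beyond the scatter), so this position responds strongly to a change far smaller than replacing the whole aromatic group. The furan ring itself therefore does not set the weak value of compound 3: a 1.6-fold lower number from compound 2 to compound 4 (0.21 log units; within the scatter) and a 2.0-fold higher number from compound 1 to compound 4 (0.30 log units; within the scatter) both lie within the scatter. Nothing shown here explains the effect of this exchange. Open, going by these compounds, is how an ethyl group, a methoxy group or an amine at this position would compare with methyl.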